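Series notes: trifluoromethoxy analogue of compound 3

A few compounds are considered here, and "the series" means these few. Any claim that something is new, unique, unknown or untested is made for them only; others in the source may bear on it.

Within the data shown here, the three measured members share one core and differ only in the group on the outer aromatic ring. Compound 1 `CCOC(=O)CCCCCOc1cccc(CN(C(=O)c2ccc(-c3cccc(N(C)C)c3)cc2)C(C)C)c1` carries dimethylamino there, compound 2 `CCOC(=O)CCCCCOc1cccc(CN(C(=O)c2ccc(-c3cccc(C(C)=O)c3)cc2)C(C)C)c1` acetyl and compound 3 `CCOC(=O)CCCCCOc1cccc(CN(C(=O)c2ccc(-c3cccc(OCC)c3)cc2)C(C)C)c1` ethoxy. In an ADME assay on Raji cells (Homo sapiens) for cytotoxicity, read by CellTiter-Glo and resazurin assay, with a stated time of 72 h (on this read-out higher numbers stand for an effect only at larger amounts of compound and lower numbers for an effect already at smaller amounts), compound 1 gives > 26000 nM, which is a limit of the assay and not a number. Compound 2 gives > 26000 nM in this assay, again a limit. Compound 3 gives > 22300 nM in this assay, also a limit. Compound 3 thus stands at a limit, like everything else measured here. Two of the three values sit at the limit of > 26000 nM in this assay, at which 2 of the 3 values shown sit, and one at the limit of > 22300 nM in this assay, at which 1 of the 3 values shown sits, so the steps a step that the two limits leave unreadable from compound 1 to compound 2, a step that the two limits leave unreadable from compound 1 to compound 3 and a step that the two limits leave unreadable from compound 2 to compound 3 are unreadable in both size and direction.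

Compound 4 `CCOC(=O)CCCCCOc1cccc(CN(C(=O)c2ccc(-c3cccc(OC(F)(F)F)c3)cc2)C(C)C)c1` differs from compound 3 by trifluoromethyl in place of ethyl on an oxygen on an aromatic ring, that is ethoxy to trifluoromethoxy. The measured steps bear on it only in that none of the three groups tried on this ring brought the value below a limit. With no readable step to set a size, no step beyond the scatter is expected in this assay. Compound 4 is expected at 30000 nM, within 10000 nM to 100000 nM, and will probably be reported as a limit again. The step that the limit leaves unreadable from compound 3 to compound 4 that this estimate means is expected to be flat. Whether the trifluoromethoxy group changes this picture is what the coming measurement has to tell.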

Compound 4, half-maximal effective concentration: > 26000 nM
Compound 4 ended at the assay's limit (the forecaster's own chance of this, stated with the estimate: 80%); the middle value lies beyond the limit too.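

Compound 4 gives > 26000 nM in this assay, again a limit of the assay and not a number. All four values are limits, and the steps linking compound 4 with compound 1, compound 2 and compound 3 cannot be read in size or direction. The compounds shown leave open whether any group on the outer aromatic ring gives a value inside the assay's range.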